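The compounds below may be only part of what the source reports. "The series", "measured", "known", "first", "only" and "open" are said of these compounds alone.

Measured compounds in an assay on CHO cells for agonist activity at Free fatty acid receptor 1 (Homo sapiens), read by luminescence, with a stated time of 20 s, in the presence of a further agent that is not named here; a higher number here means that more compound is needed for the effect, a lower number that less compound is needed:
- compound 1 `Cc1c(Cl)cccc1-c1cccc(COc2ccc([C@H](CC(=O)O)c3nccn3C)cc2)c1` gives 22000 nM
- compound 2 `Cn1ccnc1[C@@H](CC(=O)O)c1ccc(OCc2cccc(-c3ccc(Cl)cc3Cl)c2)cc1` gives 30000 nM
- compound 3 `Cc1ccc(F)cc1-c1cccc(COc2ccc([C@H](CC(=O)O)c3nccn3C)cc2)c1` gives 42000 nM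

Compound 3 carries the highest number of the three, but its separation from compound 2 is a 1.4-fold higher number from compound 2 to compound 3 (0.15 log units; within the scatter) and from compound 1 is a 1.9-fold higher number from compound 1 to compound 3 (0.28 log units; within the scatter), both within the scatter, so no ordering among the three is supported. Compound 4 `Cc1cc(Cl)ccc1-c1cccc(COc2ccc([C@H](CC(=O)O)c3nccn3C)cc2)c1` differs from compound 3 by 4-chloro-2-methylphenyl in place of 5-fluoro-2-methylphenyl on an aromatic carbon. The comparable steps are the swaps of the distal aryl ring among the measured compounds: a 1.4-fold higher number from compound 1 to compound 2 (0.13 log units; within the scatter), a 1.9-fold higher number from compound 1 to compound 3 (0.28 log units; within the scatter) and a 1.4-fold higher number from compound 2 to compound 3 (0.15 log units; within the scatter), none of which leaves the scatter. A step of no consequence beyond the scatter is therefore expected for compound 4, a 1.4-fold lower number from compound 3 to compound 4 (0.15 log units; within the scatter). Compound 4 is estimated at 30000 nM, with a range of 12000 nM to 75000 nM.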

Compound 4, half-maximal effective concentration: 10000 nM
Beside the measured number, compound 4's estimate is 3.0-fold (0.48 log units) above it; the measured number lies below the stated range.
By their numbers in this assay, from the lowest: compound 4; then compounds 1, 2 and 3 (each within the scatter of the next).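

In this assay the distal aryl ring now yields steps beyond the scatter, which no earlier swap did: 4-chloro-2-methylphenyl in place of 5-fluoro-2-methylphenyl gives a 4.2-fold lower number from compound 3 to compound 4 (0.62 log units; beyond the scatter) and the same ring also gives a 3.0-fold lower number from compound 2 to compound 4 (0.48 log units; beyond the scatter) and a 2.2-fold lower number from compound 1 to compound 4 (0.34 log units; beyond the scatter) as its other two steps. The last step shows that 4-chloro-2-methylphenyl and 3-chloro-2-methylphenyl are not interchangeable here, so where the chloro stands on this ring matters in these compounds. No supporting data bear on the reason for these steps.

Going by these compounds, whether trifluoromethyl or nitrile in place of the chloro of 4-chloro-2-methylphenyl would keep the lower number stays open.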